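This account rests on a few compounds, and the source may have more. Where it says the series, first, only, none or still open, it means among the compounds named here.

Measured so far:
compound 1 `O=S(=O)(Nc1ccc(-c2nc3ccccc3o2)cc1)c1cccc(Cl)c1` — an assay on cells for inhibition of HSP60/HSP10 (Homo sapiens), with a stated time of 60 min; on this read-out higher numbers stand for weaker inhibition and lower numbers for stronger inhibition: 54000 nM
compound 2 `O=S(=O)(Nc1ccc(-c2nc3ccccc3o2)cc1)c1ccc(C(F)(F)F)cc1` — this assay: 50000 nM
compound 3 `C=Cc1ccc(S(=O)(=O)Nc2ccc3oc(-c4ccccc4)nc3c2)cc1` — this assay: > 100000 nM

For compound 3 the entry in this assay is a limit of the assay and not a number, (the limit of > 100000 nM in this assay, at which 1 of the 3 values shown sits). Of the two numbers, compound 2 gives the lowest, and compound 1 stands nearest to it, within the scatter, so the two are not separable in this read-out.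

Compound 4 `O=S(=O)(Nc1ccc(-c2nc3ccccc3o2)cc1)c1ccc(O)cc1` is still to be measured. It differs from compound 2 as hydroxy in place of trifluoromethyl on an aromatic carbon. Within the data shown here, no measured pair in this set differs at that position, so the step has no measured counterpart and the data give no direction for it. The expected step from compound 2 to compound 4 is a 1.2-fold higher number from compound 2 to compound 4 (0.08 log units; within the scatter), which is read as no change beyond the scatter. For compound 4 the estimate in this assay is 60000 nM, with a range from 25000 nM to 140000 nM. Given where the upper end of that range sits, a limit rather than a number is also expected as a possible outcome.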

Compound 4, half-maximal inhibitory concentration: 78000 nM
Beside the measured number, compound 4's estimate is 1.3-fold (0.11 log units) below it; the range from low to high includes it.
By their numbers in this assay, from the lowest: compounds 2, 1 and 4 (each within the scatter of the next). At a limit, above all of these: compound 3.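

Hydroxy in place of trifluoromethyl on this aromatic carbon gives the first measured step at the position in this assay, and it is a 1.6-fold higher number from compound 2 to compound 4 (0.19 log units; within the scatter), so these two groups are not separated by this read-out. With 4-hydroxyphenyl in place of 3-chlorophenyl on the sulfonyl sulfur, the step is a 1.4-fold higher number from compound 1 to compound 4 (0.16 log units; within the scatter), which also does not separate the two aryl groups. No measurement shown here gives a cause for either step.

Still open, as far as these compounds go, is whether an amine, a carboxylic acid or a longer chain on this aromatic carbon would give a step beyond the scatter in this assay. Also open, from the compounds shown here alone, is whether any change on the sulfonyl side of the shared core can give a number separable from those of compound 1, compound 2 and compound 4.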